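Phenol Replaces Fluorine on the Biaryl Ring

A few compounds are considered here, and "the series" means these few. Any claim that something is new, unique, unknown or untested is made for them only; others in the source may bear on it.

Compound 1 `CCCCCCCCS(=O)(=O)Nc1ccc(-c2ccccc2Cl)cc1C(=O)O` and compound 2 `CCCCCCCCS(=O)(=O)Nc1ccc(-c2cccc(F)c2)cc1C(=O)O` share the same core and differ only in the ring attached to it. In an assay on mitochondria (strain BALB/c) for inhibition of glycerol-3-phosphate acyltransferase 1, mitochondrial (Mus musculus), read by scintillation counting, with a stated time of 10 min (a higher number here means a weaker inhibitor, a lower number a stronger inhibitor), compound 1 gives 14400 nM. In this assay, among the compounds with values here, compound 2 gives 37600 nM, the higher of the two numbers; the only known step, a 2.6-fold higher number from compound 1 to compound 2 (0.42 log units; beyond the scatter), separates them. Compound 3 `CCCCCCCCS(=O)(=O)Nc1ccc(-c2ccc(O)cc2)cc1C(=O)O` has not been measured. It differs from compound 2 by 4-hydroxyphenyl in place of 3-fluorophenyl on an aromatic carbon. Within the data shown here, the one measured step touched the same ring and was modest, but it exchanged one halogen-bearing ring for another and tells nothing about a hydroxyl group. Among the measured compounds shown here, no measured step therefore bears directly on this change, and the expectation stays close to the current number with a wide range. Compound 3 is expected at 30000 nM in this assay, between 9000 nM and 100000 nM. The expected step is a 1.3-fold lower number from compound 2 to compound 3 (0.10 log units; within the scatter), which need not exceed the scatter.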

Compound 3, half-maximal inhibitory concentration: 47300 nM
For compound 3 the middle estimate is 1.6-fold (0.20 log units) below the measured one; measured number inside the range.
By their numbers in this assay, from the lowest: compound 1; then compounds 2 and 3 (each within the scatter of the next).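

In this assay the exchange of 3-fluorophenyl for 4-hydroxyphenyl gives a 1.3-fold higher number from compound 2 to compound 3 (0.10 log units; within the scatter) and so adds a hydrogen-bond donor and a hydrogen-bond acceptor on this ring without a change that can be told from the scatter. Against the 2-chlorophenyl ring of compound 1, the 4-hydroxyphenyl ring gives a 3.3-fold higher number from compound 1 to compound 3 (0.52 log units; beyond the scatter) and thus joins the 3-fluorophenyl ring of compound 2 on the side of higher numbers, which leaves compound 1 with the lowest number of the three. Nothing measured here explains these numbers.

Each step changes the group on the ring and its place together, and the compounds shown do not separate the two. On these data alone, whether an amine or a methoxy group on this ring would give a number nearer that of compound 1 or that of compound 3 stays open.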